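The source may report more compounds than this note shows. Statements on the series, on what has been measured and on what is new or still open speak of the compounds shown alone.

The measured compounds, each in an ADME assay on Vero cells (Chlorocebus sabaeus) for cytotoxicity, read by MTT assay, with a stated time of 72 h; a higher number here means a weaker inhibitor, a lower number a stronger inhibitor:

Compound 1, `COc1ccc(C2CC(c3cc4ccccc4o3)=NN2C(=O)c2ccncc2)c(O)c1`: compound 1 gives > 190000 nM, which is a limit of the assay rather than a number.
Compound 2, `O=C(c1ccncc1)N1N=C(c2cc3ccccc3o2)CC1c1ccc(O)cc1`: compound 2 gives > 200000 nM, again a limit.
Compound 3, `O=C(c1ccncc1)N1N=C(c2cc3ccccc3o2)CC1c1ccccc1[N+](=O)[O-]`: compound 3 gives > 245000 nM, also a limit.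

Compound 2 therefore stands only at a limit in this assay, and the two other values shown are limits as well, so none of the three can be placed above or below another. Compound 4, `O=C(c1ccncc1)N1N=C(c2cc3ccccc3o2)CC1/C=C/c1ccccc1`, has not yet been measured. It differs from compound 2 in one place: 2-phenylethenyl in place of 4-hydroxyphenyl on a saturated ring carbon. Going by the values given here, the steps that bear on this change are a step that the two limits leave unreadable from compound 1 to compound 2 and a step that the two limits leave unreadable from compound 2 to compound 3, both of which stay unreadable because every end sits at a limit (the limit of > 190000 nM in this assay, at which 1 of the 3 values shown sits, (the limit of > 200000 nM in this assay, at which 1 of the 3 values shown sits), (the limit of > 245000 nM in this assay, at which 1 of the 3 values shown sits)). Swapping the group on that saturated ring carbon has so far produced nothing visible, so the step of a number no higher from compound 2 to compound 4 (the limit leaves the size open) is expected to stay within the scatter, in no particular direction. Compound 4 is estimated at 200000 nM in this assay, with a range from 100000 nM to 400000 nM, most likely again reported only as a limit.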

Compound 4, half-maximal inhibitory concentration: > 212000 nM
Compound 4: no number, only a limit; the forecaster's own chance of this, stated with the estimate: 80%; middle value at least 1.0-fold (0.02 log units) from the limit.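

In this assay compound 4 gives > 212000 nM, a limit and not a number, so its steps to compound 1, compound 2 and compound 3 cannot be read. The compounds shown leave open whether changing the group on that saturated ring carbon alters this read-out at all.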